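Swapping Methoxy for 3,4-Dichlorophenyl: What Cytotoxicity to Expect

The compounds below may be only part of what the source reports. "The series", "measured", "known", "first", "only" and "open" are said of these compounds alone.

Compound 1 `C=C[C@@](C)(/C=C/c1ccc(OC)cc1)CCC=C(C)C`: > 52000 nM
Compound 2 `C=C[C@@](C)(/C=C/c1ccc(O)cc1)CC/C=C(\C)C=O`: > 52000 nM
Compound 3 `COc1ccc(/C=C/[C@@](C)(/C=C/c2ccc(O)cc2)CCC=C(C)C)cc1`: > 52000 nM

All three measured compounds were tested in a functional assay on HepG2 cells (Homo sapiens) for cytotoxicity, with a stated time of 72 h; a higher number here means that more compound is needed for the effect, a lower number that less compound is needed. For compound 1 the value shown is a limit of the assay and not a number. Compound 2 likewise reaches only that limit. Compound 3 likewise reaches only that limit. Among the measured compounds shown here, compound 1 therefore stands exactly where the other two stand, at the limit of > 52000 nM in this assay, at which 3 of the 3 values shown sit, and no measured compound can be set apart from another. For the measured compounds named here, no step between measured compounds is available, so the numbers so far give no direction at all.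

Compound 4 `C=C[C@@](C)(/C=C/c1ccc(-c2ccc(Cl)c(Cl)c2)cc1)CCC=C(C)C` differs from compound 1 in one place: 3,4-dichlorophenyl in place of methoxy on an aromatic carbon. Going by the values given here, because every measured value sits at the limit of > 52000 nM in this assay, at which 3 of the 3 values shown sit, there is no measured step on which to build. The step from compound 1 to compound 4 is expected to be small and uncertain, an at least 1.1-fold lower number from compound 1 to compound 4 (0.06 log units; that floor lies within the scatter). Compound 4 is expected to give about 45000 nM in this assay, with a likely range from 12000 nM to 150000 nM.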

Compound 4, half-maximal effective concentration: > 52000 nM
Compound 4 gave a limit, no number; the forecaster's own chance of this, stated with the estimate: 55%; at least 1.1-fold (0.06 log units) between middle value and limit.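

Among the compounds shown here, compound 4, like compound 1, reaches only a limit of the assay in this assay, so no step between compound 1 and compound 4 can be read: the limit of > 52000 nM in this assay, at which 4 of the 4 values shown sit. The compounds shown leave open whether 3,4-dichlorophenyl in place of methoxy changes the concentration needed for the effect at all, and in which direction.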